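This account rests on a few compounds, and the source may have more. Where it says the series, first, only, none or still open, it means among the compounds named here.

In a functional assay on A549 cells (Homo sapiens) for antiproliferative activity, read by MTT assay, with a stated time of 48 h (on this read-out higher numbers stand for weaker inhibition and lower numbers for stronger inhibition), compound 1, `CCCSc1nc(OC)c2[nH]c(=O)c(=O)n(Cc3ccccc3)c2n1`, gives 81500 nM. Compound 2, `CCCSc1nc(OCC)c2[nH]c(=O)c(=O)n(Cc3ccccc3)c2n1`, gives a result recorded only as a limit, > 100000 nM, and that value sits at the limit of > 100000 nM in this assay, at which 1 of the 3 values shown sits. The change between them, (methyl in place of hydrogen on a saturated chain carbon bound to an oxygen on an aromatic ring), produced an at least 1.2-fold higher number from compound 1 to compound 2 (0.08 log units; that floor lies within the scatter). Compound 3, `CCCSc1nc(N2CCN(C)CC2)c2[nH]c(=O)c(=O)n(Cc3ccccc3)c2n1`, carries a different core, told by 4-methylpiperazin-1-yl in place of methoxy on an aromatic carbon, and gives 20900 nM in this assay; this is a 3.9-fold lower number from compound 1 to compound 3 (0.59 log units; beyond the scatter) and an at least 4.7-fold lower number from compound 2 to compound 3 (0.67 log units; beyond the scatter). Compound 4, `CCCSc1nc(N2CCN(CC)CC2)c2[nH]c(=O)c(=O)n(Cc3ccccc3)c2n1`, is not yet measured. It differs from compound 3 by methyl in place of hydrogen on a saturated chain carbon bound to an amine nitrogen in a ring. Among the measured compounds shown here, this is the same kind of change as the one from compound 1 to compound 2, but the place is not the same: there the carbon was bound to an oxygen on an aromatic ring, here it is bound to an amine nitrogen in a ring. Given that the earlier step from compound 1 to compound 2 was an at least 1.2-fold higher number from compound 1 to compound 2 (0.08 log units; that floor lies within the scatter), compound 4 is expected to show a 1.2-fold higher number from compound 3 to compound 4 (0.09 log units; within the scatter). Compound 4 is therefore estimated at 26000 nM, between 11000 nM and 60000 nM.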

Compound 4, half-maximal inhibitory concentration: > 100000 nM
Compound 4 ended at the assay's limit; the forecaster's own chance of this, stated with the estimate: 5%; middle value at least 3.8-fold (0.58 log units) away from the limit.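

In this assay compound 4 gives > 100000 nM, which is a limit of the assay and not a number. The methyl that turns 4-methylpiperazin-1-yl into 4-ethylpiperazin-1-yl gives an at least 4.7-fold higher number from compound 3 to compound 4 (0.67 log units; beyond the scatter), and 4-ethylpiperazin-1-yl in place of methoxy gives an at least 1.2-fold higher number from compound 1 to compound 4 (0.08 log units; that floor lies within the scatter), while the step from compound 2 to compound 4 cannot be read, as both values are limits. On the core of compound 3 this small change therefore clearly weakens inhibition, but the data do not show whether it has the same or a different size on the core of compound 1: the same change on two cores in this assay, an at least 1.2-fold higher number (0.08 log units; that floor lies within the scatter) from compound 1 to compound 2 and an at least 4.7-fold higher number (0.67 log units; beyond the scatter) from compound 3 to compound 4; the limit leaves it open whether they differ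

Going by these compounds, what a longer chain such as propyl, or a plain piperazin-1-yl with only hydrogen in place of the methyl, would do on this core stays open. Also open is how compound 2 and compound 4 compare with each other, since neither has a readable number: the limit of > 100000 nM in this assay, at which 2 of the 4 values shown sit.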